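A few compounds are considered here, and "the series" means these few. Any claim that something is new, unique, unknown or untested is made for them only; others in the source may bear on it.

Of the compounds shown here, two have so far been measured in a functional assay on SF-539 cells (Homo sapiens) for antiproliferative activity, read by sulforhodamine B assay, with a stated time of 48 h; on this read-out higher numbers stand for weaker inhibition of growth and lower numbers for stronger inhibition of growth. Compound 1, with the structure `COc1ccc(OC)c(/C=C/c2nnc(Nc3ccc(Cl)cc3)o2)c1`, gives 60500 nM in this assay. Compound 2, with the structure `COc1ccc(OC)c(/C=C/C(=O)N/N=C/c2ccc(Cl)cc2)c1`, gives 3160 nM in this assay. Going by the values given here, of the two numbers, the one for compound 2 is the lowest, and the gap to compound 1 lies beyond the usual scatter of repeated measurements, so compound 2 is the stronger inhibitor of growth among the pair.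

Compound 3, with the structure `COc1ccc(OC)c(/C=C/C(=O)N/N=C/c2ccccc2)c1`, has not been measured yet. It differs from compound 2 in one place only: hydrogen in place of chloro on an aromatic carbon. Among the compounds with values here, no pair of measured compounds differs by this change, so there is no directly comparable step to lean on. On general experience, removing such a group tends to cost a little potency or to leave it unchanged, and a step of modest size toward a higher number, or none beyond the scatter, is expected. For compound 3 in this assay the estimated value is 6000 nM, with a likely range from 2000 nM to 20000 nM. That estimate means an expected step of a 1.9-fold higher number from compound 2 to compound 3 (0.28 log units; within the scatter).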

Compound 3, concentration for total growth inhibition: 25100 nM
Compound 3: middle estimate off by 4.2-fold (0.62 log units), on the low side; the measured number lies above the stated range.
By their numbers in this assay, from the lowest: compound 2; then compound 3; then compound 1.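

In this assay, replacing the chloro group of the 4-chlorophenyl ring with hydrogen gives a 7.9-fold higher number from compound 2 to compound 3 (0.90 log units; beyond the scatter). Going by these compounds alone, this is the first direct reading of this position. The two earlier compounds differ in more than one place and could not isolate the contribution of the chloro group. It shows that, in this pair, growth inhibition is sensitive to a change of just one heavy atom, one that adds or removes no ring, hydrogen-bond donor, hydrogen-bond acceptor or net charge, and that the chloro compound is the stronger inhibitor of growth.

The compounds shown leave open whether chlorine is special here or whether fluoro, bromo, methyl or methoxy at the same place would serve as well, and whether a chloro group on another carbon of this ring would have a similar effect. There is also no measurement here that explains why this change has such an effect on growth inhibition.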